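The compounds below may be only part of what the source reports. "The series", "measured", "known", "first", "only" and "open" are said of these compounds alone.

Measured in a functional assay on PC-3 cells (Homo sapiens) for inhibition, read by MTT assay, with a stated time of 96 h; on this read-out lower numbers stand for stronger inhibition of growth and higher numbers for weaker inhibition of growth:
- compound 1 `O=C(NCCCCCCSSCCCCCCNC(=O)c1cc(-c2ccncc2)n[nH]1)c1cc(-c2ccncc2)n[nH]1`: 4740 nM
- compound 2 `C=CCOC(=O)SCCCCCCNC(=O)c1cc(-c2ccncc2)n[nH]1`: 24800 nM

Compound 2 holds the higher of these two numbers, so it is the weaker growth inhibitor of the pair, and the gap lies beyond the scatter. Compound 3 `CSCCCCCCNC(=O)c1cc(-c2ccncc2)n[nH]1` keeps the rest of compound 2 but carries methyl in place of allyloxycarbonyl on a sulfur. Within the data shown here, no measured pair shows this change directly, so the expectation is loose. In this assay, a small move towards weaker inhibition is expected, perhaps none beyond the scatter, and the estimated step is a 1.6-fold higher number from compound 2 to compound 3 (0.21 log units; within the scatter). The estimated value for compound 3 is 40000 nM, within a range of 15000 nM to 100000 nM.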

Compound 3, concentration for 50% growth inhibition: > 50000 nM
Compound 3 gave a limit, no number; the forecaster's own chance of this, stated with the estimate: 25%; middle value at least 1.2-fold (0.09 log units) away from the limit.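

On the sulfur, methyl in place of allyloxycarbonyl gives in this assay an at least 2.0-fold higher number from compound 2 to compound 3 (0.30 log units; that floor lies within the scatter), so this change brings no gain in growth inhibition. Compound 3 gives > 50000 nM, which is a limit and not a number. The step is therefore only a floor, and its full size cannot be read because compound 3 sits at that limit: the limit of > 50000 nM in this assay, at which 1 of the 3 values shown sits.

Still open, going by these compounds, is how a free thiol or an acetyl group on this sulfur would compare with allyloxycarbonyl and methyl. On these data alone, the effect of a longer chain also remains open.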